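Changing the Ester Group of Compound 3

The compounds below may be only part of what the source reports. "The series", "measured", "known", "first", "only" and "open" are said of these compounds alone.

Compound 1 `COc1ccc(/C=C/C(=O)c2ccc(OC)c3c2OC(C)(C)C=C3)cc1O`: 450 nM
Compound 2 `COc1ccc(/C=C/C(=O)c2ccc(OC)c3c2OC(C)(C)C=C3)cc1OCCCN(C)C`: 5550 nM
Compound 3 `COc1ccc(/C=C/C(=O)c2ccc(OC)c3c2OC(C)(C)C=C3)cc1OC(=O)C1CC1`: 220 nM

These values come from a functional assay on HepG2 cells (Homo sapiens) for cytotoxicity, read by MTT assay (a lower number here means a stronger inhibitor, a higher number a weaker inhibitor), and compound 3 has the lowest number of the three. Going by the values given here, compound 4 `COc1ccc(/C=C/C(=O)c2ccc(OC)c3c2OC(C)(C)C=C3)cc1OC(=O)c1ccc(Br)cc1` has 4-bromophenyl in place of cyclopropyl on a carbonyl carbon and no measured step makes this exact swap. The closest guide is the cyclopropylcarbonyl step (a 2.0-fold lower number from compound 1 to compound 3 (0.31 log units; beyond the scatter)). The 3-(dimethylamino)propyl step was far larger (a 12-fold higher number from compound 1 to compound 2 (1.09 log units; beyond the scatter)) but does not keep the carbonyl. Compounds 3 and 4 both keep it, so only a small step is expected (a 1.4-fold higher number from compound 3 to compound 4 (0.13 log units; within the scatter)). Compound 4 is estimated at 300 nM (expected range 100 nM to 900 nM).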

Compound 4, half-maximal inhibitory concentration: 680 nM
Compound 4: the middle estimate sits 2.3-fold (0.36 log units) below what was measured, and the stated range covers the measured number.
By their numbers in this assay, from the lowest: compound 3; then compounds 1 and 4 (each within the scatter of the next); then compound 2.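

The group on the carbonyl carbon matters at this position, not only the presence of the carbonyl: in this assay, 4-bromophenyl in place of cyclopropyl gives (a 3.1-fold higher number from compound 3 to compound 4 (0.49 log units; beyond the scatter)). The 4-bromophenyl ester is far from the 3-(dimethylamino)propyl compound (an 8.2-fold lower number from compound 2 to compound 4 (0.91 log units; beyond the scatter)), yet it cannot be told apart from the compound with hydrogen on that oxygen (a 1.5-fold higher number from compound 1 to compound 4 (0.18 log units; within the scatter)). Nothing available explains these differences.

As far as these compounds go, whether the bromine or the ring drives the step stays open. So does how a plain phenyl or a longer alkyl chain on the carbonyl carbon would read.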